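Swapping nitro for acetamido: compound 2 to compound 3

The source may report more compounds than this note shows. Statements on the series, on what has been measured and on what is new or still open speak of the compounds shown alone.

So far, two compounds have been measured. In an ADME assay on L02 cells (Homo sapiens) for cytotoxicity, read by MTT assay, with a stated time of 24 h (on this read-out lower numbers stand for stronger inhibition and higher numbers for weaker inhibition), compound 1 (`COc1ccc(/C=C2\CN(C)C/C(=C\c3cccnc3)C2=O)c(OC)c1OC`) gives a half-maximal inhibitory concentration of 13600 nM as a true number. Compound 2 (`O=C1/C(=C/c2cccnc2)CN(S(=O)(=O)c2ccc([N+](=O)[O-])cc2)C/C1=C\c1ccccc1F`) reads > 20000 nM in this assay and this is a limit of the assay, not a number. Compound 2 therefore has no exact place on the scale.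

Compound 3 (`CC(=O)Nc1ccc(S(=O)(=O)N2C/C(=C\c3cccnc3)C(=O)/C(=C/c3ccccc3F)C2)cc1`) has not yet been measured. It keeps the rest of compound 2 and changes one group: acetamido in place of nitro on an aromatic carbon, para to a large group (acetamido in place of nitro on an aromatic carbon). Among the measured compounds shown here, no measured pair shows what this swap does, so there is no firm basis for predicting a direction. Compound 1 (13600 nM) shows that a related structure can give a true number, so a true number remains possible for compound 3. The expected change is no larger than the usual scatter (a number no higher from compound 2 to compound 3 (the limit leaves the size open)). The estimated value for compound 3 is 20000 nM with an expected range from 9000 nM to 40000 nM as its bounds.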

Compound 3, half-maximal inhibitory concentration: 15600 nM
The estimate for compound 3 lay 1.3-fold (0.11 log units) above the measured number; the range from low to high includes it.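

In this assay, among the compounds shown here, the swap of nitro for acetamido on this aromatic carbon, para to a large group, provides the first pair of compounds that differ in one place, and it reads as an at least 1.2-fold lower number from compound 2 to compound 3 (0.10 log units; that floor lies within the scatter). Compound 3 gives 15600 nM, a true number, so the 4-acetamidophenyl group yields a value with an exact place on the scale, which the 4-nitrophenyl group in the otherwise identical compound 2 did not. The full size of the change stays unknown because compound 2 reads only as a limit of the assay, so the pair sets a floor on the step and nothing more: the limit of > 20000 nM in this assay, at which 1 of the 3 values shown sits.

From the compounds shown here alone, how an amine or a carboxylic acid on this same aromatic carbon would read remains open, so a single swap cannot yet show how the number at this position follows the group placed there. Going by these compounds, it is also open whether the change from 4-nitrophenyl to 4-acetamidophenyl would give a step of similar direction when the remainder of the molecule differs, and a pair in which both members give true numbers would be needed to settle its size.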